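The compounds below may be only part of what the source reports. "The series", "measured", "known", "first", "only" and "open" are said of these compounds alone.

Measured compounds:
- compound 1 `Cc1cccc(-n2nc(-c3ccccc3)nc2CNc2ccc(C(=O)NO)cc2)c1` gives 66%
- compound 2 `O=C(NO)c1ccc(NCc2nc(-c3ccc(C(F)(F)F)cc3)nn2-c2ccccc2)cc1` gives 41.6%
- compound 3 `O=C(NO)c1ccc(NCc2nc(-c3ccc(Cl)cc3)nn2-c2ccccc2)cc1` gives 67.2%

These three share one core and were tested in an assay on Sf9 cells for inhibition of protein deacetylase HDAC6 (Homo sapiens), read by fluorescence, with a stated time of 40 min, tested at 100 nM; a higher number here means more inhibition at the concentration tested (going by the name of the read-out), a lower number less inhibition. Compound 1 stands second highest of the three numbers; its nearest neighbour is compound 3, whose value lies within the usual scatter of that of compound 1, so no order can be read between the two. Among the measured compounds shown here, compound 2 stands furthest away, well below, and the one step that connects two measured compounds is a number 25.6 percentage points higher from compound 2 to compound 3 (beyond the scatter).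

The unmeasured compound 4 `Cc1cc(C)cc(-n2nc(-c3ccccc3)nc2CNc2ccc(C(=O)NO)cc2)c1` differs from compound 1 in one place: methyl in place of hydrogen on an aromatic carbon. Cut one bond further out, this turns a 3-methylphenyl into a 3,5-dimethylphenyl. For the measured compounds named here, none of the measured steps touches this part of the molecule; the only measured step, from compound 2 to compound 3, changes a different ring. There is therefore nothing in the data to point to a change in either direction, and a step no larger than the scatter is expected. For compound 4 the estimate is 63%, with a range of 45% to 79%, which is an expected step of a number 3 percentage points lower from compound 1 to compound 4 (within the scatter).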

Compound 4, a percentage reported as inhibition, at one concentration (the size of the read-out at that concentration, not a potency): 49.8%
Estimate against measurement, compound 4: 13.2 percentage points above; measured number inside the range.
By their numbers in this assay, from the lowest: compounds 2 and 4 (each within the scatter of the next); then compounds 1 and 3 (each within the scatter of the next).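

In this assay, going from 3-methylphenyl to 3,5-dimethylphenyl gives a number 16.2 percentage points lower from compound 1 to compound 4 (beyond the scatter). Among the compounds shown here, the only earlier step changed a substituent on the other aromatic ring, so this is the first sign that this ring also responds to a small change: a methyl of one carbon, added on an aromatic carbon meta to a large group and meta to a methyl group, is enough to move the number beyond the scatter. No measurement available here explains the drop.

As far as these compounds go, it remains open whether the drop is specific to methyl or would also follow a fluorine, a methoxy group or an amine at this place. Also open, from the compounds shown here alone, is how a plain phenyl here, with no methyl at all and the rest of compound 1 unchanged, would compare.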